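Fluoro for Nitro on a Weakly Active Thione Core

This account rests on a few compounds, and the source may have more. Where it says the series, first, only, none or still open, it means among the compounds named here.

Compound 3 `O=[N+]([O-])c1ccc(-c2nssc2=S)cc1` was tested in a functional assay on MCF7 cells (Homo sapiens) for antiproliferative activity, read by MTT assay, with a stated time of 72 h; on this read-out higher numbers stand for weaker inhibition of growth and lower numbers for stronger inhibition of growth. In this assay compound 3 reaches only a limit, > 10000 nM, and not a number. Its closest measured relative is compound 2 `S=c1ssnc1-c1ccccc1`, which bears hydrogen where compound 3 bears nitro. In this assay compound 2 also gives only a limit, > 10000 nM. The step from compound 2 to compound 3 is therefore a step that the two limits leave unreadable from compound 2 to compound 3, so its size cannot be read. This comes from the limit of > 10000 nM in this assay, at which 2 of the 3 values shown sit. Compound 1 `Fc1ccc(-c2nss/c2=N\c2ccccc2)cc1`, built on a different core but carrying a fluoro group, gives 10000 nM in this assay as a measured number. Compound 4 `Fc1ccc(-c2nssc2=S)cc1` is the compound to be measured next; it differs from compound 3 by fluoro in place of nitro on an aromatic carbon. Among the measured compounds shown here, no measured step shows what this particular exchange does on the core of compound 3. With all three known values sitting at or near the same level, the step from compound 3 to compound 4 is expected to be a number no higher from compound 3 to compound 4 (the limit leaves the size open). Compound 4 is therefore estimated at 10000 nM, with a range from 4000 nM to 30000 nM.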

Compound 4, concentration for 50% growth inhibition: > 10000 nM
Compound 4: no number, only a limit (the forecaster's own chance of this, stated with the estimate: 60%); the middle value sits exactly at the limit.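

Compound 2, compound 3 and compound 4 each give only a limit in this assay, so no step among them can be read: the limit of > 10000 nM in this assay, at which 3 of the 4 values shown sit.

The compounds shown leave open whether hydrogen, nitro and fluoro on this aromatic carbon differ at all in their inhibition of growth.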